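The compounds below may be only part of what the source reports. "The series", "measured", "known", "first", "only" and "open" are said of these compounds alone.

Among the compounds with values here, compound 2 `COc1ccc(-c2cccc(C(=O)N(C)Cc3ccccn3)c2)cc1S(=O)(=O)Nc1cccc(NCCNC(=O)c2cccc(C)c2)c1` gives the lowest of the two numbers so far, 107 nM in a functional assay on CHO-RD-HGA16 cells for agonist activity at Orexin receptor type 2 (Homo sapiens), read by fluorescence and calcium flux, with a stated time of 30 min (a lower number here means that less compound is needed, a higher number that more compound is needed for the effect), while compound 1 `COc1ccc(-c2cccc(C(=O)NCCN(C)C)c2)cc1S(=O)(=O)Nc1cccc(NCCNC(=O)c2cccc(C)c2)c1` gives 1630 nM. Within the data shown here, the only measured step, a 15-fold lower number from compound 1 to compound 2 (1.18 log units; beyond the scatter), swapped the entire group on the carbonyl carbon, so it speaks to the present change only loosely. Compound 3 `COc1ccc(-c2cccc(C(=O)NCc3ccccn3)c2)cc1S(=O)(=O)Nc1cccc(NCCNC(=O)c2cccc(C)c2)c1` differs from compound 2 by hydrogen in place of methyl on an amide-type nitrogen. Among the measured compounds shown here, no measured step isolates this change, so a step no larger than the scatter is expected, if anything a slight loss: a 1.9-fold higher number from compound 2 to compound 3 (0.27 log units; within the scatter). Compound 3 is therefore expected to give about 200 nM, within 60 nM to 650 nM.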

Compound 3, half-maximal effective concentration: 464 nM
Beside the measured number, compound 3's estimate is 2.3-fold (0.37 log units) below it; low and high end bracket the measured number.
By their numbers in this assay, from the lowest: compound 2; then compound 3; then compound 1.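

Hydrogen in place of methyl on the amide-type nitrogen gives a 4.3-fold higher number from compound 2 to compound 3 (0.64 log units; beyond the scatter) and shows that this single methyl counts at this position. With hydrogen on that nitrogen in both compounds, pyridin-2-yl in place of (dimethylamino)methyl gives a 3.5-fold lower number from compound 1 to compound 3 (0.55 log units; beyond the scatter) and so accounts for only part of the large earlier step, with the methyl supplying the rest. Nothing available explains either step. Still open, as far as these compounds go, is whether ethyl or a longer chain on that nitrogen would lower the number further, and whether phenyl could stand in for pyridin-2-yl.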